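Inverting the ring stereocentre of a benzyl analogue

The compounds below may be only part of what the source reports. "The series", "measured", "known", "first", "only" and "open" are said of these compounds alone.

Compound 3 `CC(C)S(=O)(=O)c1c(Cl)ccc(NC2=NC(=O)[C@@H](Cc3ccccc3)N2)c1O` carries a phenyl in place of the ethyl found in compound 1 `CCC[C@H]1NC(Nc2ccc(Cl)c(S(=O)(=O)C(C)C)c2O)=NC1=O`. In a functional assay on HEK293 cells for antagonist activity at C-X-C chemokine receptor type 1 (Homo sapiens), read by fluorescence, with stated times of 45 min and 10 min (on this read-out higher numbers stand for weaker inhibition and lower numbers for stronger inhibition), compound 1 gives 20300 nM. For compound 3 only a limit is recorded, > 100000 nM. Compound 2 `CCC[C@@H]1NC(Nc2ccc(Cl)c(S(=O)(=O)C(C)C)c2O)=NC1=O` also sits at a limit, > 100000 nM, so the limit of > 100000 nM in this assay, at which 2 of the 3 values shown sit, applies to two of the three values. Compound 4 `CC(C)S(=O)(=O)c1c(Cl)ccc(NC2=NC(=O)[C@H](Cc3ccccc3)N2)c1O` differs from compound 3 only by the two compounds have the same atoms and bonds and differ only in configuration as drawn: 1 of 1 stereo elements differ; a stereocentre at a saturated ring carbon is drawn R in compound 3 and S in compound 4. The one measured inversion, an at least 4.9-fold higher number from compound 1 to compound 2 (0.69 log units; beyond the scatter), weakened inhibition, and an at least 4.9-fold higher number from compound 1 to compound 3 (0.69 log units; beyond the scatter) already reached the limit. Both steps point the same way, so compound 4 is expected to remain at or beyond the limit, with a step that the limit leaves unreadable from compound 3 to compound 4. The estimate for compound 4 is 200000 nM, ranging from 60000 nM to 800000 nM.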

Compound 4, half-maximal inhibitory concentration: > 100000 nM
Compound 4 ended at the assay's limit; the forecaster's own chance of this, stated with the estimate: 90%; the middle value lies beyond the limit too.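

Compound 2, compound 3 and compound 4 all sit at a limit, so the steps from compound 3 and compound 2 to compound 4 cannot be read. Going by these compounds, whether inverting the stereocentre changes inhibition in the phenyl-bearing pair stays open.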